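Swapping the Benzyl Arm: Expected Cytotoxicity of Compound 4

The source may report more compounds than this note shows. Statements on the series, on what has been measured and on what is new or still open speak of the compounds shown alone.

The measured compounds, with their results in a toxicity assay on MDCK cells (Canis lupus familiaris) for cytotoxicity, read by crystal violet staining, with a stated time of 48 h; on this read-out lower numbers stand for higher toxicity in this test and higher numbers for lower toxicity in this test:

Compound 1, `Cc1ccc2cc(C(C)N(Cc3ccc(F)cc3)Cc3ccc(C(C)C)cc3)c(=O)[nH]c2c1`, gives > 33000 nM, which is a limit of the assay and not a number.
Compound 2, `CCCc1ccc2[nH]c(=O)c(CN(Cc3ccc(F)cc3)Cc3ccc(C(C)(C)C)cc3)cc2c1`, gives 8400 nM.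
Compound 3, `CCCOc1ccc(CN(Cc2ccc(C(C)(C)C)cc2)Cc2cc3cc(C)ccc3[nH]c2=O)cc1`, gives > 5000 nM, again a limit rather than a number.

Compound 3 therefore stands at the limit of > 5000 nM in this assay, at which 1 of the 3 values shown sits; only compound 2 has a real number, and compound 1 sits at the limit of > 33000 nM in this assay, at which 1 of the 3 values shown sits. Nothing in these three values places compound 3 above or below the others. Two of the three results are limits, and the third lies close to them.

Compound 4 is `Cc1ccc2[nH]c(=O)c(CN(Cc3ccc(C(C)(C)C)cc3)[C@@H](C)c3ccc(F)cc3)cc2c1`. It differs from compound 3 in one place: 1-(4-fluorophenyl)ethyl in place of 4-propoxybenzyl on an amine nitrogen. The rest of the molecule, including the shared core and the other benzyl arm on the nitrogen, stays the same.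

Among the measured compounds shown here, no measured pair differs in just this way, so the size of the step has to be guessed. Compound 1, which carries the same 1-(4-fluorophenyl)ethyl group, reached a limit, and compound 2 with a plain benzyl arm gave a modest number. On that basis I expect the step that the limit leaves unreadable from compound 3 to compound 4 to stay within the usual scatter, or to move slightly towards lower toxicity. My estimate for compound 4 is 15000 nM, with a likely range from 5000 nM to 40000 nM, and a fair chance that the assay again reports only a limit.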

Compound 4, half-maximal cytotoxic concentration: > 5000 nM
Compound 4: no number, only a limit; the forecaster's own chance of this, stated with the estimate: 50%; the middle value is on the limit's open side.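

Among the compounds shown here, compound 3 and compound 4 each give only a limit, not a number, in this assay, and no step between them can be read for the swap of 4-propoxybenzyl to 1-(4-fluorophenyl)ethyl. The compounds shown leave open whether this swap changes toxicity in this test at all, and in which direction.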